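This account rests on a few compounds, and the source may have more. Where it says the series, first, only, none or still open, it means among the compounds named here.

Two sulfonamides sharing one core were tested in an assay on cells for inhibition of HSP60/HSP10 (Homo sapiens), with a stated time of 60 min; on this read-out lower numbers stand for stronger inhibition and higher numbers for weaker inhibition. Compound 1, `O=S(=O)(Nc1ccc(-c2nc3ccccc3o2)cc1)c1ccccc1Cl`, gives > 100000 nM in this assay, a value that is a limit of the assay rather than a measured number. Compound 2, `C=Cc1ccc(S(=O)(=O)Nc2ccc3oc(-c4ccccc4)nc3c2)cc1`, gives > 100000 nM in this assay, again a limit and not a number. Compound 2 therefore stands at the limit, as the limit of > 100000 nM in this assay, at which 2 of the 2 values shown sit, records. Compound 3, `O=S(=O)(Nc1ccc2oc(-c3ccccc3)nc2c1)c1cccs1`, has not yet been measured; it differs from compound 2 by thiophen-2-yl in place of 4-vinylphenyl on a sulfonyl sulfur. Among the measured compounds shown here, because both measured values are limits, no step between measured compounds is available to guide an expectation. The step from compound 2 to compound 3 is expected to be a number no higher from compound 2 to compound 3 (the limit leaves the size open), meaning no change beyond the usual scatter is expected. Compound 3 is therefore estimated at 100000 nM, within a range from 30000 nM to 300000 nM, with a good chance that this assay again reports only a limit.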

Compound 3, half-maximal inhibitory concentration: 90000 nM
Estimate against measurement, compound 3: 1.1-fold (0.05 log units) above; low and high end bracket the measured number.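

In this assay, among the compounds shown here, compound 3 gives 90000 nM, the first actual number at this position rather than a limit. Thiophen-2-yl in place of 4-vinylphenyl on a sulfonyl sulfur gives an at least 1.1-fold lower number from compound 2 to compound 3 (0.04 log units; that floor lies within the scatter), so no real gain can be claimed, but a five-membered aromatic ring with a sulfur atom at this place does yield a readable value. The true size of the step stays unknown, and limits still dominate the series: the limit of > 100000 nM in this assay, at which 2 of the 3 values shown sit.

As far as these compounds go, whether any group on the sulfonyl sulfur can bring the number far down remains open, for example an amine, a carboxylic acid or a longer chain. Compound 1 differs from the other two compounds in more than one place, so its steps to them cannot be read.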